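Cytotoxicity of quinolinone series: chloro to fluoro on the aryl

The source may hold more compounds than are shown below. What is called first, only, known or untested is meant among the compounds shown, and "the series" means these compounds.

Compounds compared in an ADME assay on HepG2 2.2.15 cells (Homo sapiens) for cytotoxicity; on this read-out lower numbers stand for higher toxicity in this test and higher numbers for lower toxicity in this test: compound 1 `Nc1c(-c2ccccc2F)c2cc(Cl)ccc2[nH]c1=O` gives 767000 nM, and compound 3 `O=c1[nH]c2ccc(Cl)cc2c(-c2ccccc2Cl)c1CCO` gives 1720000 nM, the highest number among those measured, with compound 1 a lower value beyond the scatter; these two differ in two places, so only their values are compared. Compound 2 `O=c1[nH]c2ccc(Cl)cc2c(-c2ccccc2)c1CCO` reached only a limit of the assay, > 4910000 nM, as noted in the limit of > 4910000 nM in this assay, at which 1 of the 3 values shown sits. Within the data shown here, the single measured step, an at least 2.8-fold lower number from compound 2 to compound 3 (0.45 log units; beyond the scatter), is chloro in place of hydrogen on an aromatic carbon.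

Compound 4 `O=c1[nH]c2ccc(Cl)cc2c(-c2ccccc2F)c1CCO` differs from compound 3 by fluoro in place of chloro on an aromatic carbon. The measured step concerns the same position but a different exchange, so it gives only an indirect bearing; the halogen is retained, and a step no larger than that one is expected, most likely within the scatter or a small rise, giving an estimated 1.3-fold higher number from compound 3 to compound 4 (0.11 log units; within the scatter). For compound 4 the expected value in this assay is 2200000 nM, within 800000 nM to 6000000 nM.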

Compound 4, half-maximal cytotoxic concentration: > 2990000 nM
Compound 4: only a limit was reported; the forecaster's own chance of this, stated with the estimate: 25%; middle value at least 1.3-fold (0.13 log units) from the limit.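

In this assay, the change from 2-chlorophenyl to 2-fluorophenyl gives an at least 1.7-fold higher number from compound 3 to compound 4 (0.24 log units; that floor lies within the scatter), so the fluoro compound may sit no higher than the chloro compound once scatter is allowed for, and any real rise remains unproven. With the 2-fluorophenyl group held constant, the series now has its first one-place comparison at the other substituent, and it is clear: an at least 3.8-fold higher number from compound 1 to compound 4 (0.59 log units; beyond the scatter). The value of compound 4 is only a limit, and the step between compound 2 and compound 4 cannot be read: the limit of > 2990000 nM in this assay, at which 1 of the 4 values shown sits.

As far as these compounds go, how far fluoro truly differs from chloro or hydrogen on this aromatic carbon remains open. Also open, from the compounds shown here alone, is how bromo or methoxy would read there, and how a carboxylic acid or a longer chain would compare with 2-hydroxyethyl.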